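This account rests on a few compounds, and the source may have more. Where it says the series, first, only, none or still open, it means among the compounds named here.

Measured so far in a functional assay on A-431 cells (Homo sapiens) for cytotoxicity; a higher number here means that more compound is needed for the effect, a lower number that less compound is needed:
- Compound 1 `COC1=C(C)C(=O)/C(=C(O)/C=C/c2cccc(OC)c2)C(=O)C1(C)C`: 4.5 ug/mL
- Compound 2 `COC1=C(C)C(=O)/C(=C(O)/C=C/c2c(C)cccc2C)C(=O)C1(C)C`: 10.1 ug/mL

Of these two, compound 2 has the higher number at 10.1 ug/mL, so more of it is needed for the effect. Within the data shown here, the one measured step, a 2.2-fold higher number from compound 1 to compound 2 (0.35 log units; beyond the scatter), is modest but lies beyond the usual scatter.

The next molecule, compound 3 `COC1=C(C)C(=O)/C(=C(O)/C=C/c2c(C)cc(C)cc2C)C(=O)C1(C)C`, keeps the shared core and differs from compound 2 at a single place: methyl in place of hydrogen on an aromatic carbon. Put simply, a methyl takes the place of a hydrogen on an aromatic carbon.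

Among the measured compounds shown here, no measured pair tests this exact change. For the measured compounds named here, the only available guide is the step of a 2.2-fold higher number from compound 1 to compound 2 (0.35 log units; beyond the scatter), which exchanged one whole substituted aromatic group for another, so it bears on this question only weakly. A single added methyl is a smaller edit, and it is expected to shift the number less than that step did, with no firm direction. The expected change is a 1.1-fold higher number from compound 2 to compound 3 (0.04 log units; within the scatter), which would stay within the scatter.

For compound 3 the estimated value is 11 ug/mL, with an expected range from 5 ug/mL to 24 ug/mL.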

Compound 3, concentration for half-maximal effect: 20 ug/mL
Compound 3: the middle estimate sits 1.8-fold (0.26 log units) below what was measured; the measured number falls inside the stated range.
By their numbers in this assay, from the lowest: compound 1; then compounds 2 and 3 (each within the scatter of the next).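

This position, the aromatic carbon para to a large group and meta to two methyl groups, now has a direct test. The earlier pair could not give one, as it exchanged one whole substituted aromatic group for another. In this assay the added methyl gives a 2.0-fold higher number from compound 2 to compound 3 (0.30 log units; within the scatter) and so compound 2 and compound 3 cannot be ranked, which means that this one extra carbon on the ring has no readable effect in this cytotoxicity read-out. Nothing measured alongside these numbers offers an explanation for this result.

Among these compounds, a methyl is only one possible group at this carbon, so it remains open how an amine, a carboxylic acid, a chlorine atom or a longer chain such as propyl would read there. Among the compounds shown here, also open is whether a methyl at this same carbon would read the same way on a ring without the two other methyl groups, since compound 2 and compound 3 both carry them and only this one pair tests the change.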